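Replacing a ringed side chain with a ring-free one

The compounds below may be only part of what the source reports. "The series", "measured", "known", "first", "only" and "open" are said of these compounds alone.

Three close relatives share one core and differ only in the group on their triple bond: compound 1 `CCN(CC)CCNC(=O)C1CC(C(CC)(CC)c2ccc(C#CC(C)(O)CC)c(C)c2)=CN1CC`, compound 2 `CCN(CC)CCNC(=O)C1CC(C(CC)(CC)c2ccc(C#CC(O)C3CCC3)c(C)c2)=CN1CC` and compound 3 `CCN(CC)CCNC(=O)C1CC(C(CC)(CC)c2ccc(C#CC(O)C3CCCCC3)c(C)c2)=CN1CC`. In a functional assay on MCF7 cells (Homo sapiens) for antiproliferative activity, read by MTT assay, with a stated time of 24 h (a higher number here means a weaker inhibitor, a lower number a stronger inhibitor), compound 1 gives 2780 nM, compound 2 gives 1280 nM and compound 3 gives 3070 nM. That places compound 3 level with compound 1, as a 1.1-fold higher number from compound 1 to compound 3 (0.04 log units; within the scatter) shows, while a 2.4-fold higher number from compound 2 to compound 3 (0.38 log units; beyond the scatter) marks its only clear gap.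

Compound 4 `CCN(CC)CCNC(=O)C1CC(C(CC)(CC)c2ccc(/C=C/C(O)(CC)CC)c(C)c2)=CN1CC` makes a larger change: a group of 8 heavy atoms (7 carbon, 1 oxygen; no ring) in place of a group of 10 heavy atoms (9 carbon, 1 oxygen; one six-membered non-aromatic ring of carbon only), on an aromatic carbon. Within the data shown here, the new group has no ring and a double bond, and no measured pair tests that swap of bond type. The nearest guides are modest: a 2.2-fold lower number from compound 1 to compound 2 (0.34 log units; beyond the scatter) and a 2.4-fold higher number from compound 2 to compound 3 (0.38 log units; beyond the scatter). Compound 1, which also lacks a ring, sits at 2780 nM, so no step beyond the scatter is expected in this assay. The estimate is a 1.2-fold lower number from compound 3 to compound 4 (0.09 log units; within the scatter). For compound 4 the expected value is 2500 nM, with an estimated range from 1100 nM to 5500 nM.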

Compound 4, half-maximal inhibitory concentration: 690 nM
Beside the measured number, compound 4's estimate is 3.6-fold (0.56 log units) above it, outside the stated range (below it).
By their numbers in this assay, from the lowest: compounds 4 and 2 (each within the scatter of the next); then compounds 1 and 3 (each within the scatter of the next).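

In this assay, the ring-free group on a double bond in compound 4 gives a clear gain over the cyclohexyl group (a 4.4-fold lower number from compound 3 to compound 4 (0.65 log units; beyond the scatter)) and also over a group with no ring on a triple bond (a 4.0-fold lower number from compound 1 to compound 4 (0.61 log units; beyond the scatter)), so lacking a ring does not by itself set the number at this position. Compound 4 stands level with the cyclobutyl compound (a 1.9-fold lower number from compound 2 to compound 4 (0.27 log units; within the scatter)), which shows that groups with and without a ring can read alike here. No measurement at hand explains these steps.

The bond and the rest of the group change together, so a comparison of the same group on a double bond and on a triple bond would be needed to separate them. On these data alone, whether an amine or a carboxylic acid in place of the hydroxyl would keep this level also stays open.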